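Expected Growth Inhibition of a Cyanophenyl Analogue

The source may report more compounds than this note shows. Statements on the series, on what has been measured and on what is new or still open speak of the compounds shown alone.

Compound 1 `O=C1Nc2ccc([N+](=O)[O-])cc2/C1=N/NC(=S)Nc1ccc(F)cc1`: 15%
Compound 2 `O=C1Nc2ccc([N+](=O)[O-])cc2/C1=N/NC(=S)Nc1ccc(I)cc1`: 10%

In a functional assay on the whole organism for inhibition, with Lemna aequinoctialis as the target, tested at 100 ug/mL (on this read-out higher numbers stand for more inhibition of growth at the one concentration tested and lower numbers for less inhibition of growth), compound 2 gives 10%, and its number sits alongside that of compound 1, the two within the scatter of each other. Compound 3 `N#Cc1cccc(NC(=S)N/N=C2\C(=O)Nc3ccc([N+](=O)[O-])cc32)c1` carries 3-cyanophenyl in place of 4-iodophenyl on an amide-type nitrogen. Among the compounds with values here, the only measured step, a number 5 percentage points lower from compound 1 to compound 2 (within the scatter), exchanged one halogen for another on the aromatic carbon and stayed within the scatter; no measured step involves a nitrile, so its effect is unknown. Compound 3 is therefore expected to give 12% in this assay, with a range from 0% to 35%. The expected step for compound 3 is a number 2 percentage points higher from compound 2 to compound 3 (within the scatter), nothing beyond the scatter.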

Compound 3, percent growth inhibition at one concentration: 15%
Beside the measured number, compound 3's estimate is 3 percentage points below it, and the stated range covers the measured number.
By their numbers in this assay, from the lowest: compounds 2, 1 and 3 (each within the scatter of the next).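

With a nitrile now on the aryl group at the amide-type nitrogen, this assay shows a number 5 percentage points higher from compound 2 to compound 3 (within the scatter) and no change at the digits printed from compound 1 to compound 3 (within the scatter). The change at this place therefore goes beyond exchanging one halogen for another, yet 3-cyanophenyl cannot be told apart from 4-iodophenyl or 4-fluorophenyl in this read-out. Nothing available explains this result. As far as these compounds go, it remains open whether any group on this nitrogen gives a step beyond the scatter, for instance a phenyl ring carrying an amine or a carboxylic acid.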